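The compounds below may be only part of what the source reports. "The series", "measured", "known", "first", "only" and "open" are said of these compounds alone.

Values so far in a functional assay on MIA PaCa-2 cells (Homo sapiens) for inhibition; on this read-out lower numbers stand for stronger inhibition and higher numbers for weaker inhibition

Compound 1 `O=C1O/C(=C\Cn2cc(C(F)(F)F)c(=O)[nH]c2=O)C(OCc2ccccc2)=C1OCc1ccccc1` gives 30000 nM
Compound 2 `O=C1O/C(=C\Cn2ccc(=O)[nH]c2=O)C(OCc2ccccc2)=C1OCc1ccccc1` gives 30000 nM
Compound 3 `O=C1O/C(=C\Cn2cc(Cl)c(=O)[nH]c2=O)C(OCc2ccccc2)=C1OCc1ccccc1` gives 40000 nM

Compound 3 (40000 nM) lies within the scatter of both compound 1 and compound 2, so the three cannot be told apart. Compound 4 `O=C1O/C(=C\Cn2cc(Br)c(=O)[nH]c2=O)C(OCc2ccccc2)=C1OCc1ccccc1` carries bromo in place of chloro on an aromatic carbon. Three measured steps change the group on this same carbon: a 1.3-fold higher number from compound 2 to compound 3 (0.12 log units; within the scatter) and a 1.3-fold higher number from compound 1 to compound 3 (0.12 log units; within the scatter) and no change at the digits printed from compound 1 to compound 2 (within the scatter) all stay within the scatter. On that evidence, no step beyond the scatter is expected in this assay for compound 4. Compound 4 is estimated at 35000 nM with an expected range of 18000 nM to 60000 nM in this read-out. This estimate means a 1.1-fold lower number from compound 3 to compound 4 (0.06 log units; within the scatter) as the expected step.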

Compound 4, half-maximal inhibitory concentration: 80000 nM
The estimate for compound 4 lay 2.3-fold (0.36 log units) below the measured number; the measured number lies above the stated range.
By their numbers in this assay, from the lowest: compounds 1, 2, 3 and 4 (each within the scatter of the next, the first and the last beyond it).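

In this assay, going by these compounds alone, bromo gives the first steps at this position that leave the scatter: a 2.7-fold higher number from compound 2 to compound 4 (0.43 log units; beyond the scatter) against hydrogen and a 2.7-fold higher number from compound 1 to compound 4 (0.43 log units; beyond the scatter) against trifluoromethyl, both modest. Chloro to bromo gives a 2.0-fold higher number from compound 3 to compound 4 (0.30 log units; within the scatter) and so does not separate these two groups. Nothing measured here accounts for the higher number with bromo.

As far as these compounds go, what an amine, a carboxylic acid or a longer chain on this carbon would do remains open. So does whether any group here can give a lower number than hydrogen.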